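The source may report more compounds than this note shows. Statements on the series, on what has been measured and on what is new or still open speak of the compounds shown alone.

Compound 1 `COc1ccc(C(=O)c2sc(Nc3ccccc3)c(C(=O)O)c2C)cc1`: 52.6%
Compound 2 `COc1ccc(C(=O)c2sc(Nc3ccc(C)cc3)c(C(=O)O)c2C)cc1`: "not active" (no number reported)
Compound 3 `COc1ccc(Nc2sc(C(=O)c3ccc(OC)cc3)c(C)c2C(=O)O)cc1`: 38.5%

In a functional assay, with a stated time of 150 min, tested at 25 ug/mL (on this read-out lower numbers stand for a weaker effect and higher numbers for a stronger effect at the one concentration tested), compound 1 gives 52.6%. Compound 2 is reported only as "not active" (no number reported), with no number. Compound 3 gives 38.5%, the lowest of the two numbers, the step being a number 14.1 percentage points lower from compound 1 to compound 3 (beyond the scatter). Compound 4 `COc1ccc(C(=O)c2sc(Nc3ccc(F)cc3)c(C(=O)O)c2C)cc1` differs from compound 3 in one place: fluoro in place of methoxy on an aromatic carbon. Going by the values given here, no measured step bears directly on this change; the one step known, a number 14.1 percentage points lower from compound 1 to compound 3 (beyond the scatter), shows methoxy at this place lowering the read-out, while compound 2, carrying another group there, gave no number at all. Compound 4 is therefore expected to move by a number 3.5 percentage points higher from compound 3 to compound 4 (within the scatter), a small rise within the scatter, giving an estimated 42% with a range from 18% to 60%.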

Compound 4, a percentage reported as activity, at one concentration (the size of the read-out at that concentration, not a potency): 0.836%
Beside the measured number, compound 4's estimate is 41.2 percentage points above it, and the stated range ends above it.
By their numbers in this assay, from the lowest: compound 4; then compound 3; then compound 1.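

In this assay, going by these compounds alone, this place proves far more sensitive than the earlier compounds showed: fluoro gives a number 37.7 percentage points lower from compound 3 to compound 4 (beyond the scatter), and against hydrogen it gives a number 51.8 percentage points lower from compound 1 to compound 4 (beyond the scatter), leaving almost no read-out. The order does not follow the heavy-atom count, since fluoro, with one heavy atom, falls below methoxy, with two, while hydrogen stands above both. No available evidence accounts for this drop. Steps to compound 2 cannot be read, as it has no number. Going by these compounds, whether an amine or a carboxylic acid at this place would hold the read-out of compound 1 remains open.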